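Shortening the Amine Side Chain of a Diaryl Urea

This account rests on a few compounds, and the source may have more. Where it says the series, first, only, none or still open, it means among the compounds named here.

Compound 2 `CCN(CC)CCn1cnnc1-c1cc(Oc2ccc(NC(=O)Nc3ccc(Cl)cc3Cl)cc2F)ccn1` is one of two diaryl ureas tested in a functional assay on NCI-H460 cells (Homo sapiens) for antiproliferative activity, read by MTT assay, with a stated time of 72 h (on this read-out higher numbers stand for weaker inhibition and lower numbers for stronger inhibition), where compound 2 gives 5380 nM. Compound 1 `CCN(CC)CCn1cnnc1-c1cc(Oc2ccc(NC(=O)Nc3ccc(F)c(Cl)c3)cc2F)ccn1` gives 7390 nM in this assay. Within the data shown here, the only measured step, a 1.4-fold lower number from compound 1 to compound 2 (0.14 log units; within the scatter), leaves compound 2 with the lower of the two numbers, but the gap lies within the scatter, so neither compound can be called the stronger. Compound 3 `CN(C)CCCn1cnnc1-c1cc(Oc2ccc(NC(=O)Nc3ccc(Cl)cc3Cl)cc2F)ccn1` differs from compound 2 in a different part of the molecule: (dimethylamino)methyl in place of diethylamino on a saturated chain carbon, two bonds along the chain from an aromatic nitrogen. Among the measured compounds shown here, no measured step touches this amine side chain, and the single measured step concerns the halogenated phenyl on the urea instead, so there is nothing in the data to suggest a shift beyond the scatter. Compound 3 is therefore expected to give about 5500 nM in this assay, an estimated step of a 1.0-fold higher number from compound 2 to compound 3 (0.01 log units; within the scatter), with a plausible range from 2000 nM to 15000 nM.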

Compound 3, half-maximal inhibitory concentration: 3680 nM
Compound 3: the middle estimate sits 1.5-fold (0.17 log units) above what was measured; the measured number falls inside the stated range.
By their numbers in this assay, from the lowest: compounds 3, 2 and 1 (each within the scatter of the next).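

Among these compounds, exchanging the 2-(diethylamino)ethyl chain of compound 2 for the 3-(dimethylamino)propyl chain of compound 3 gives, in this assay, a 1.5-fold lower number from compound 2 to compound 3 (0.16 log units; within the scatter) and is the only step here that touches the amine side chain, so this position accepts the exchange without a difference that can be told from the scatter. The exchange alters the chain length and the groups on the nitrogen together, so this pair cannot separate the two changes. No measured evidence bears on this result.

Open, on these data alone, is whether 2-(dimethylamino)ethyl or 3-(diethylamino)propyl at this position would tell the effects of chain length and nitrogen substituents apart. Also open, as far as these compounds go, is whether a ring amine such as morpholine or piperidine at the end of the chain would give numbers in the same range.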